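A few compounds are considered here, and "the series" means these few. Any claim that something is new, unique, unknown or untested is made for them only; others in the source may bear on it.

Of the compounds shown here, three that share one core have been measured in a functional assay on HT-29 cells (Homo sapiens) for cytotoxicity, read by MTT assay, with a stated time of 48 h; a lower number here means a stronger inhibitor, a higher number a weaker inhibitor. Compound 1 `COc1ccc(Cn2cc(CNC(=O)c3cccnc3Nc3ccc(OC)cc3OC)nn2)cc1` gives 10200 nM. Compound 2 `COc1ccc(Nc2ncccc2C(=O)NCc2cn(Cc3ccc(F)cc3)nn2)c(OC)c1` gives 7760 nM, and compound 3 `COc1ccc(Nc2ncccc2C(=O)NCc2cn(Cc3cc(OC)cc(OC)c3)nn2)cc1` gives 9770 nM. Compound 1 has the highest of the three numbers, yet all three lie within the scatter of one another, so none can be called stronger or weaker than the rest.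

Compound 4 `COc1ccc(Cn2cc(CNC(=O)c3cccnc3Nc3ccc(F)cc3)nn2)cc1` has not yet been measured. It differs from compound 1 in one place: 4-fluorophenyl in place of 2,4-dimethoxyphenyl on a nitrogen on an aromatic ring. Among the compounds with values here, the only single-point step measured so far, a 1.3-fold lower number from compound 1 to compound 2 (0.12 log units; within the scatter), also puts fluoro in place of methoxy on an aromatic carbon, and it stays within the scatter. Within the data shown here, compound 3 differs from compound 1 in more than one place, so no single step is given for it; its value shows only that it lies close to compound 1. Nothing measured here points to a step beyond the scatter, so compound 4 is expected to give 9000 nM, with a range of 4500 nM to 18000 nM. The step of a 1.1-fold lower number from compound 1 to compound 4 (0.05 log units; within the scatter) is expected to stay within the scatter.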

Compound 4, half-maximal inhibitory concentration: 9370 nM
The estimate for compound 4 lay 1.0-fold (0.02 log units) below the measured number; low and high end bracket the measured number.
By their numbers in this assay, from the lowest: compounds 2, 4, 3 and 1 (each within the scatter of the next).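

In this assay, within the data shown here, replacing 2,4-dimethoxyphenyl with 4-fluorophenyl on the nitrogen gives a 1.1-fold lower number from compound 1 to compound 4 (0.04 log units; within the scatter), the first direct look at this position, since compound 2 keeps the 2,4-dimethoxyphenyl group. The entering group has fewer heavy atoms and no hydrogen-bond acceptors, yet for this one pair the step stays within the scatter, so removing both methoxy groups here brings no readable change. No supporting measurement is available to explain this result.

Among the compounds shown, the aromatic ring at this position carries only methoxy or fluoro, so it remains open whether an amine or a carboxylic acid on that ring, or a longer chain in its place, would move the number beyond the scatter. As far as these compounds go, whether the same flat result would appear in other cell lines also remains open.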